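A few compounds are considered here, and "the series" means these few. Any claim that something is new, unique, unknown or untested is made for them only; others in the source may bear on it.

Measured so far in a functional assay on CCRF-CEM cells (Homo sapiens); a higher number here means that more compound is tolerated, a lower number that less compound is tolerated:
compound 1 `Cc1cn([C@@H]2O[C@@H]3COC(=O)[C@]3(OS(C)(=O)=O)[C@H]2O)c(=O)[nH]c1=O` gives 160000 nM
compound 2 `CCOC(=O)CNC(=O)NC1=CS(=O)(=O)O[C@@]12[C@@H](CO[Si](C)(C)C(C)(C)C)O[C@@H](n1cc(C)c(=O)n(C)c1=O)[C@@H]2O[Si](C)(C)C(C)(C)C` gives 5020 nM

Compound 2 stands at the lowest of the two numbers in this assay; compound 1 is the nearest, and its number is higher by a margin beyond the usual scatter. Among the compounds with values here, no step between these two is computed, since they differ in more than one place, so only the two values themselves can be set side by side.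

Compound 3 `Cc1cn([C@@H]2O[C@H](CO[Si](C)(C)C(C)(C)C)[C@@]3(OS(=O)(=O)C=C3NCCC(=O)O)[C@H]2O[Si](C)(C)C(C)(C)C)c(=O)n(C)c1=O` has not been measured. It differs from compound 2 in one place: 2-carboxyethyl in place of ((ethoxycarbonyl)methyl)carbamoyl on an amine nitrogen. Within the data shown here, no measured step shows what such a change does, so no direction can be taken from the data. The expected step in this assay is a 1.6-fold higher number from compound 2 to compound 3 (0.20 log units; within the scatter), a modest rise at most and likely within the scatter. Compound 3 is therefore expected to give about 8000 nM in this assay, within a range from 2000 nM to 40000 nM.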

Compound 3, half-maximal cytotoxic concentration: 19400 nM
Beside the measured number, compound 3's estimate is 2.4-fold (0.38 log units) below it; the range from low to high includes it.
By their numbers in this assay, from the lowest: compound 2; then compound 3; then compound 1.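

In this assay, the group on the amine nitrogen now has a one-place reading: 2-carboxyethyl in place of ((ethoxycarbonyl)methyl)carbamoyl gives a 3.9-fold higher number from compound 2 to compound 3 (0.59 log units; beyond the scatter), a modest step. The group at this position therefore does move the cytotoxic concentration, and here the smaller group, with 5 heavy atoms against 9, goes with more compound being tolerated. No supporting measurement bears on why the number rises.

The change replaces the whole group at once, so the compounds shown leave open whether the step follows the loss of the carbamoyl part, the shift from ethyl ester to carboxylic acid, or the chain itself. The ethyl ester of the 2-carboxyethyl chain, a longer chain such as 3-carboxypropyl, or a free amine at this nitrogen would separate these readings.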